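Butyl to cyclopentyl on an aromatic nitrogen: a second test

The source may report more compounds than this note shows. Statements on the series, on what has been measured and on what is new or still open speak of the compounds shown alone.

Measured compounds:
- compound 1, `CCCCn1cnc2c(NCc3ccc(C(=O)Nc4ccccc4N)cc3)nc(Cl)nc21`: 6.8%
- compound 2, `Nc1ccccc1NC(=O)c1ccc(CNc2nc(Cl)nc3c2ncn3C2CCCC2)cc1`: 54.7%
- compound 3, `CCCCn1cnc2c(Nc3cccc(Cl)c3)nc(NCOCc3ccc(C(=O)Nc4ccccc4N)cc3)nc21`: 30.6%

In a functional assay on HepG2 cells (Homo sapiens) for antiproliferative activity, read by CCK-8 assay, with a stated time of 72 h, tested at 2 uM (a lower number here means a weaker effect, a higher number a stronger effect of the compound at the concentration tested), compound 1 gives 6.8%, while compound 2 gives 54.7%. The two differ in one place, (cyclopentyl in place of butyl on an aromatic nitrogen), and this single change made a large step: a number 47.9 percentage points higher from compound 1 to compound 2 (beyond the scatter).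

Compound 3, which gives 30.6% in this assay, is built on a different core; the difference between the core of compound 1 and the core of compound 3 is not broken down here. Compound 4, `Nc1ccccc1NC(=O)c1ccc(COCNc2nc(Nc3cccc(Cl)c3)c3ncn(C4CCCC4)c3n2)cc1`, has not yet been measured. It is related to compound 3 by the same change that links compound 1 to compound 2: cyclopentyl in place of butyl on an aromatic nitrogen. The place of the change is described in the same words for both pairs.

Only one earlier instance of this change exists among these compounds, so its effect on the core of compound 3 is not known. With that single precedent in mind, the step from compound 3 to compound 4 is expected to be upward but somewhat smaller than the earlier one, because a number 47.9 percentage points higher from compound 1 to compound 2 (beyond the scatter) was seen on a different core. The expected step is a number 27.4 percentage points higher from compound 3 to compound 4 (beyond the scatter). On that basis compound 4 is estimated to give 58% in this assay, with a likely range from 32% to 82%.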

Compound 4, a percentage reported as inhibition, at one concentration (the size of the read-out at that concentration, not a potency): 32.6%
For compound 4 the middle estimate is 25.4 percentage points above the measured one; measured number inside the range.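

On the core of compound 3, putting cyclopentyl in place of butyl on the aromatic nitrogen gives a number 2 percentage points higher from compound 3 to compound 4 (within the scatter) in this assay, so here the swap makes no difference that can be told from ordinary assay scatter. Among the compounds shown here, the large gain seen on the core of compound 1 therefore did not carry over to the core of compound 3, and the size of this change's effect depends on the core that bears it: the same change on two cores in this assay, a number 47.9 percentage points higher (beyond the scatter) from compound 1 to compound 2 and a number 2 percentage points higher (within the scatter) from compound 3 to compound 4, 45.9 percentage points apart, beyond the scatter of two such steps This rests on only two pairs of compounds tested at a single concentration, so it shows that the effect cannot be assumed to transfer, but it does not show which structural difference between the two cores is responsible or how the change would behave on a third core.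

The compounds shown leave open how a longer chain, such as hexyl, or a larger ring, such as cyclohexyl, on the same aromatic nitrogen would read on either core. They also leave open whether swapping the chlorine of compound 1 and compound 2 for an amine would bring the step closer to the large one or to the one within the scatter.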